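Solubility notes on a carbamoyl replacement series

The compounds below may be only part of what the source reports. "The series", "measured", "known", "first", "only" and "open" are said of these compounds alone.

Measured so far:
- compound 1, `NC(=O)c1ccccc1NC(=O)c1cc2cc([N+](=O)[O-])ccc2o1`, in a physicochemical assay for solubility (on this read-out lower numbers stand for lower solubility and higher numbers for higher solubility), compound 1 gives 5 ug/mL
- compound 2, `CC(C)(C)OC(=O)NCc1ccccc1NC(=O)c1cc2cc([N+](=O)[O-])ccc2o1`, in this assay compound 2 gives 25 ug/mL
- compound 3, `NC(=O)c1ccccc1NC(=O)c1cc2ccccc2s1`, in this assay compound 3 gives only a limit, < 5 ug/mL

Compound 1 and compound 2 share a core and differ in one place: ((tert-butoxycarbonyl)amino)methyl in place of carbamoyl on an aromatic carbon. That change gave a 5.0-fold higher number from compound 1 to compound 2 (0.70 log units; beyond the scatter).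

Compound 3 carries a different core; how the two cores differ is not broken down here. The value of compound 3 is a limit and not a number, so its place relative to compound 1 is not fixed.

Compound 4, `CC(C)(C)OC(=O)NCc1ccccc1NC(=O)c1cc2ccccc2s1`, is not yet measured. It stands to compound 3 as compound 2 stands to compound 1: ((tert-butoxycarbonyl)amino)methyl in place of carbamoyl on an aromatic carbon. The place lines of the two changes read the same word for word, so this is the same change, made a second time, now on the core of compound 3.

The expectation for compound 4 rests on the measured step of a 5.0-fold higher number from compound 1 to compound 2 (0.70 log units; beyond the scatter), carried over to the core of compound 3. The starting point is uncertain because the limit of < 5 ug/mL in this assay, at which 1 of the 3 values shown sits, leaves compound 3 without a number. A step of about an at least 2.0-fold higher number from compound 3 to compound 4 (0.30 log units; that floor lies within the scatter) is expected in this assay. For compound 4 an estimate of 10 ug/mL is made, with an expected span from 3 ug/mL to 30 ug/mL.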

Compound 4, solubility: 20 ug/mL
Compound 4: the middle estimate sits 2.0-fold (0.30 log units) below what was measured; the measured number falls inside the stated range.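

Working notes on the new step: on the core of compound 3, ((tert-butoxycarbonyl)amino)methyl in place of carbamoyl gave an at least 4.0-fold higher number from compound 3 to compound 4 (0.60 log units; beyond the scatter) in this assay, and the same change on the core of compound 1 gave a 5.0-fold higher number from compound 1 to compound 2 (0.70 log units; beyond the scatter), so the number rises on both cores shown and both steps lie beyond the scatter. The direction therefore carries over between these two cores, but the step on the core of compound 3 is only a floor, and whether the two steps match in size cannot be read: the limit of < 5 ug/mL in this assay, at which 1 of the 4 values shown sits. Two matched pairs on two cores show no rule for other cores, and they do not show which part of the entering group goes with the higher numbers.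

Open on either core is what a plain aminomethyl group, a primary amine or a carboxylic acid at that place on the aromatic carbon would give, set against both carbamoyl and ((tert-butoxycarbonyl)amino)methyl. Also open, going by these compounds, is how far the core alone moves the read-out, as the value of compound 3 is a limit and the pair of compound 3 and compound 1 differs in its core rather than in this group.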